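Two Hydroxyls Out, Two Methoxys In: Expecting Compound 3

A few compounds are considered here, and "the series" means these few. Any claim that something is new, unique, unknown or untested is made for them only; others in the source may bear on it.

Compound 1, `O=C(N/N=C/c1ccccc1O)c1ccc(-c2nc3ccccc3s2)cc1`: in an assay on isolated protein for inhibition of Maltase-glucoamylase (Homo sapiens), with a stated time of 15 min (a higher number here means a weaker inhibitor, a lower number a stronger inhibitor), compound 1 gives 5550 nM.
Compound 2, `O=C(N/N=C/c1ccc(O)cc1O)c1ccc(-c2nc3ccccc3s2)cc1`: in this assay compound 2 gives 5580 nM.

Among the compounds with values here, only two compounds have been measured, and their numbers sit side by side: compound 2 holds the higher of the two numbers, but the step between them is a 1.0-fold higher number from compound 1 to compound 2 (0.00 log units; within the scatter), so the two cannot be told apart. Compound 3, `COc1cc(/C=N/NC(=O)c2ccc(-c3nc4ccccc4s3)cc2)cc(OC)c1`, has not yet been measured. It differs from compound 2 in a single place: 3,5-dimethoxyphenyl in place of 2,4-dihydroxyphenyl on a carbon with a double bond to nitrogen. Both hydroxy groups leave and two methoxy groups arrive on a differently substituted ring, so the ring loses its hydrogen-bond donors while keeping two acceptors. Within the data shown here, the only measured step, a 1.0-fold higher number from compound 1 to compound 2 (0.00 log units; within the scatter), adds a hydroxy and changes nothing; no measured pair speaks to methoxy in place of hydroxy. In this assay compound 3 is therefore expected to land near its neighbours, estimated at 6000 nM with a range of 2000 nM to 18000 nM. The expected step from compound 2 to compound 3 is a 1.1-fold higher number from compound 2 to compound 3 (0.03 log units; within the scatter), with the wider range reflecting the absence of a measured precedent.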

Compound 3, half-maximal inhibitory concentration: 16200 nM
For compound 3 the middle estimate is 2.7-fold (0.43 log units) below the measured one; low and high end bracket the measured number.
By their numbers in this assay, from the lowest: compounds 1 and 2 (each within the scatter of the next); then compound 3.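

In this assay, the ring on the carbon with a double bond to nitrogen turns out not to be indifferent to what it carries: 3,5-dimethoxyphenyl in place of 2,4-dihydroxyphenyl gives a 2.9-fold higher number from compound 2 to compound 3 (0.46 log units; beyond the scatter), and 3,5-dimethoxyphenyl in place of 2-hydroxyphenyl gives a 2.9-fold higher number from compound 1 to compound 3 (0.47 log units; beyond the scatter). Where the added hydroxy made no readable difference, these two modest steps of similar size make compound 3 the weakest inhibitor of the three, so the first sign of sensitivity at this position comes from a change to the ring's substituents as a whole. Nothing measured here accounts for this loss of inhibition.

The change from compound 2 to compound 3 alters two things at once, the kind of group and its place on the ring, and the compounds shown cannot separate them. On these data alone, a 3,5-dihydroxyphenyl or a 2,4-dimethoxyphenyl on the same carbon would pull those two apart, and whether a ring bearing an amine or a carboxylic acid would give a lower or a higher number remains open.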